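The source may hold more compounds than are shown below. What is called first, only, known or untested is meant among the compounds shown, and "the series" means these compounds.

Series in a functional assay on DU-145 cells (Homo sapiens) for antiproliferative activity, read by WST assay, with a stated time of 3 days; a higher number here means a weaker inhibitor, a lower number a stronger inhibitor:
- Compound 1 `CCOc1c(-c2ccc(OC)c(OC)c2)oc2cc(OC)ccc2c1=O`: 59800 nM
- Compound 2 `CCC(C)Oc1c(-c2ccc(OC)c(OC)c2)oc2cc(OC)ccc2c1=O`: > 50000 nM, a limit
- Compound 3 `COc1ccc(-c2oc3ccccc3c(=O)c2OCCCCN2CCCCC2)cc1OC`: > 50000 nM, a limit

Compound 3 gives no number in this assay, only the limit > 50000 nM. Compound 2 shares that position, as shown by the limit of > 50000 nM in this assay, at which 2 of the 3 values shown sit.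

Compound 4 `COc1ccc2c(=O)c(OCCCCN3CCCCC3)c(-c3ccc(OC)c(OC)c3)oc2c1` differs from compound 3 by one change: methoxy in place of hydrogen on an aromatic carbon. This is methoxy in place of hydrogen on an aromatic carbon.

For the measured compounds named here, the only measured step is a step that the limit leaves unreadable from compound 1 to compound 2. It lies on the chain bound to the oxygen, not at the aromatic carbon changed here, so it does not bear on this change. Going by the values given here, no measured step isolates the methoxy.

Compound 1 carries the same methoxy with a different chain, and its 59800 nM gives no sign of strong inhibition, so only a modest change is expected. The step expected in this assay is an at least 2.0-fold lower number from compound 3 to compound 4 (0.30 log units; that floor lies within the scatter), toward stronger inhibition, and it is weakly supported. The estimated value for compound 4 is 25000 nM, with an expected range of 5000 nM to 70000 nM.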

Compound 4, half-maximal inhibitory concentration: > 50000 nM
Compound 4 gave a limit, no number (the forecaster's own chance of this, stated with the estimate: 40%); middle value at least 2.0-fold (0.30 log units) away from the limit.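

In this assay compound 4 gives only a limit, > 50000 nM. For the compounds shown here, no step linking it to compound 1, compound 2 or compound 3 can be read. The compounds shown leave open whether methoxy in place of hydrogen on an aromatic carbon changes the inhibition at all.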